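Compound 3 at the low end, and a pyrrolidine swap

The source may report more compounds than this note shows. Statements on the series, on what has been measured and on what is new or still open speak of the compounds shown alone.

In a physicochemical assay for solubility, read by chemiluminescence, measured as kinetic solubility (a lower number here means a less soluble compound, a higher number a more soluble compound), compound 1 (`O=C([C@@H]1CCCCN1)N1CCC2(CCN(c3nccc(NCc4ccc(Cl)cc4Cl)n3)CC2)C1`) gives 170 ug/mL and compound 2 (`O=C(C1CCCNC1)N1CCC2(CCN(c3nccc(NCc4ccc(Cl)cc4Cl)n3)CC2)C1`) gives 186 ug/mL. These two sit together, with a 1.1-fold higher number from compound 1 to compound 2 (0.04 log units; within the scatter). Compound 3 (`O=C(C1CCCCC1)N1CCC2(CCN(c3nccc(NCc4ccc(Cl)cc4Cl)n3)CC2)C1`), which carries cyclohexyl on the carbonyl carbon, stands lowest of the three at 3 ug/mL. The steps leading to it are large: a 57-fold lower number from compound 1 to compound 3 (1.75 log units; beyond the scatter) and a 62-fold lower number from compound 2 to compound 3 (1.79 log units; beyond the scatter).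

Compound 4 (`Clc1ccc(CNc2ccnc(N3CCC4(CCN(C[C@@H]5CCCN5)C4)CC3)n2)c(Cl)c1`) has not yet been measured in this assay. Its difference from compound 3 is (pyrrolidin-2-yl)methyl in place of cyclohexylcarbonyl on an amine nitrogen in a ring. In words, (pyrrolidin-2-yl)methyl stands in place of cyclohexylcarbonyl on an amine nitrogen in a ring.

The two large steps to compound 3 are the closest guide, read in reverse, since each exchanges cyclohexyl for a piperidinyl group. Among the measured compounds shown here, they are only a partial guide, as both keep the carbonyl, and no measured compound shows its loss. A large step towards a higher number is therefore expected, of about the same size as those two, and the estimate is a 53-fold higher number from compound 3 to compound 4 (1.73 log units; beyond the scatter). For compound 4 the estimated value is 160 ug/mL, with an expected range from 60 ug/mL to 320 ug/mL.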

Compound 4, solubility: 56 ug/mL
Estimate against measurement, compound 4: 2.9-fold (0.46 log units) above; measured number outside the range, below it.
By their numbers in this assay, from the lowest: compound 3; then compound 4; then compounds 1 and 2 (each within the scatter of the next).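

Among the compounds shown here, at this amine nitrogen in a ring, the result gives the first reading of a group without the carbonyl: in this assay, the (pyrrolidin-2-yl)methyl group gives a 19-fold higher number from compound 3 to compound 4 (1.27 log units; beyond the scatter), so a large rise over the cyclohexylcarbonyl compound does not depend on keeping the carbonyl. The same group does not reach the level of the two groups that keep the carbonyl and carry a piperidine ring, with a 3.3-fold lower number from compound 2 to compound 4 (0.52 log units; beyond the scatter) and a 3.0-fold lower number from compound 1 to compound 4 (0.48 log units; beyond the scatter), both modest steps but beyond the scatter. Compound 4 therefore sits between compound 3 and the pair of compounds 1 and 2, and nothing measured here explains that order.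

Because this change removes the carbonyl and alters the ring together, the compounds shown cannot say which of the two accounts for the gap to compounds 1 and 2. A (pyrrolidin-2-yl)carbonyl group or a (piperidin-3-yl)methyl group at this nitrogen would separate the two, and the mirror-image form of the (pyrrolidin-2-yl)methyl group also remains an open question.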